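The source may hold more compounds than are shown below. What is called first, only, known or untested is meant among the compounds shown, and "the series" means these compounds.

Working notes on the series. Compound 1 `Cc1cc(F)cc(-c2c([C@H](C)Nc3nc(N)nc(N)c3C#N)cc3ccc(F)cn3c2=O)c1` carries a methylfluorophenyl group on the shared core and a diamino-substituted nitrile-bearing aminopyrimidine. In an ADME assay on microsomes from liver (Mus musculus), read by LC-MS, using NADPH, with a stated time of 30 min, tested at 1 uM (on this read-out higher numbers stand for a more stable compound and lower numbers for a less stable compound), compound 1 gives < 1%, which is a limit of the assay and not a number (the limit of < 1% in this assay, at which 1 of the 3 values shown sits). Compound 2 `C[C@H](Nc1ncnc(N)c1C#N)c1cc(=O)n2cc(F)ccc2c1-c1cc(F)cc(F)c1`, with a difluorophenyl group and a single amino group on its pyrimidine, gives in this assay 57%. Compound 3 `C[C@H](Nc1nc(N)nc(N)c1C#N)c1c(-c2ccccc2)c(=O)n2cc(F)ccc2c1C1CC1`, which places a cyclopropyl group at the position in question, gives in this assay 87%, the higher of the two numbers shown, and its gap to compound 2 is beyond the scatter.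

Compound 4 `C[C@H](Nc1nc(N)nc(N)c1C#N)c1c(-c2ccccc2)c(=O)n2cc(F)ccc2c1-c1ccc(F)cc1` differs from compound 3 in one place: 4-fluorophenyl in place of cyclopropyl on an aromatic carbon. With an aryl group at this position compound 2 gives 57%. Compound 1, also with an aryl group at this position, shows only a limit of the assay. A step downward beyond the scatter, a number 37 percentage points lower from compound 3 to compound 4 (beyond the scatter), is therefore expected. Compound 4 is estimated at 50%, within 20% to 80%.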

Compound 4, percent of the compound remaining: 83%
Beside the measured number, compound 4's estimate is 33 percentage points below it; measured number above the stated range.
By their numbers in this assay, from the lowest: compound 2; then compounds 4 and 3 (each within the scatter of the next). At a limit, below all of these: compound 1.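

In this assay, within the data shown here, the exchange of cyclopropyl for 4-fluorophenyl on this aromatic carbon gives a number 4 percentage points lower from compound 3 to compound 4 (within the scatter), which is the first reading of this position with only this one place differing. In this pair the two groups cannot be told apart, although 4-fluorophenyl has 7 heavy atoms and one six-membered aromatic ring where cyclopropyl has 3 heavy atoms and one three-membered ring, while compound 1 and compound 2 differ from compound 4 in more than one place and give no reading of this position alone. Nothing measured here bears on a cause for this result.

From the compounds shown here alone, whether an amine, a carboxylic acid or a longer chain on this carbon would read alike in this assay stays open. Among these compounds, also open is whether the same exchange would read alike with the single amino group on the pyrimidine, as in compound 2.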